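From 3,4-dimethylphenyl to 4-iodophenyl on a sulfonamide nitrogen

The source may report more compounds than this note shows. Statements on the series, on what has been measured and on what is new or still open speak of the compounds shown alone.

In a functional assay on HT-29 cells (Homo sapiens) for antiproliferative activity, read by sulforhodamine B assay, with a stated time of 48 h (a lower number here means a stronger inhibitor, a higher number a weaker inhibitor), compound 1 `O=C1NCCN1c1ccc(S(=O)(=O)Nc2ccc(C3CCCCC3)cc2)cc1` reads > 1000 nM, which is a limit of the assay and not a number. Compound 2 `O=C1NCCN1c1ccc(S(=O)(=O)Nc2ccc(F)cc2)cc1` gives 370 nM, and compound 3 `Cc1ccc(NS(=O)(=O)c2ccc(N3CCNC3=O)cc2)cc1C` gives 230 nM. For the measured compounds named here, these are the only two actual numbers in the set, and they lie within the scatter of each other, so compound 3 cannot be ranked apart from compound 2.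

Compound 4 `O=C1NCCN1c1ccc(S(=O)(=O)Nc2ccc(I)cc2)cc1` has not yet been measured. It keeps the shared core and has 4-iodophenyl in place of 3,4-dimethylphenyl on a sulfonamide nitrogen.

Going by the values given here, two measured steps bear on this change. The closer one, a 1.6-fold lower number from compound 2 to compound 3 (0.21 log units; within the scatter), alters the same group on the same nitrogen and stays within the scatter. The other, an at least 2.7-fold lower number from compound 1 to compound 2 (0.43 log units; beyond the scatter), is fluoro in place of cyclohexyl and lies beyond the scatter, though it starts from a limit and so gives only a bound on its size. Compound 4 carries neither the cyclohexyl of compound 1 nor any new kind of ring, so a step of that size is not expected here. The expected change is a 1.4-fold higher number from compound 3 to compound 4 (0.14 log units; within the scatter), which would be no clear step beyond the scatter. For compound 4 the estimated value is 320 nM, with an expected range of 130 nM to 800 nM.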

Compound 4, half-maximal inhibitory concentration: 650 nM
Compound 4: middle estimate off by 2.0-fold (0.31 log units), on the low side; the measured number falls inside the stated range.
By their numbers in this assay, from the lowest: compounds 3, 2 and 4 (each within the scatter of the next, the first and the last beyond it). At a limit, above all of these: compound 1.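

In this assay, for the compounds shown here, the exchange of 3,4-dimethylphenyl for 4-iodophenyl on a sulfonamide nitrogen gives a 2.8-fold higher number from compound 3 to compound 4 (0.45 log units; beyond the scatter) and is the first change at this position between two actual numbers that lies beyond the scatter. Iodo in place of fluoro on an aromatic carbon gives a 1.8-fold higher number from compound 2 to compound 4 (0.24 log units; within the scatter) and stays within the scatter, so compound 4 cannot be ranked apart from compound 2, and only the two ends of the series, compound 3 and compound 4, separate clearly. Compound 1 stands at a limit and not at a number, so iodo in place of cyclohexyl, with an at least 1.5-fold lower number from compound 1 to compound 4 (0.18 log units; that floor lies within the scatter) as its reading, gives only a bound and no size: the limit of > 1000 nM in this assay, at which 1 of the 4 values shown sits.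

The compounds shown do not tell whether the gap between compound 3 and compound 4 follows from the iodine or from the two methyl groups, and a 4-methylphenyl or a 4-chlorophenyl group on the same nitrogen would bear on that question. From the compounds shown here alone, how an amine or a carboxylic acid on this ring would read in this assay also stays open.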